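The compounds below may be only part of what the source reports. "The series", "measured", "known", "first", "only" and "open" are said of these compounds alone.

Working notes on the series. Of the compounds shown here, three of the shared core have numbers so far, differing only in the group on the oxygen next to a carbonyl group. Compound 1 `CC(C)COC(=O)Nc1ccc([Se]C#N)cc1` carries isobutyl; in a functional assay on PC-3 cells (Homo sapiens) for cytotoxicity, read by MTT assay, with a stated time of 72 h (a higher number here means a weaker inhibitor of growth, a lower number a stronger inhibitor of growth), compound 1 gives 21600 nM. Compound 2 `C=CCOC(=O)Nc1ccc([Se]C#N)cc1` carries allyl, and in this assay compound 2 gives 17600 nM, the second highest of the three numbers, with compound 1 nearest and compound 3 furthest. Compound 3 `N#C[Se]c1ccc(NC(=O)Oc2ccccc2)cc1` carries phenyl on the oxygen next to a carbonyl group; in this assay compound 3 gives 9100 nM.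

Compound 4 `N#C[Se]c1ccc(NC(=O)OCc2ccccc2)cc1` is the unmeasured member: phenyl in place of vinyl on a saturated chain carbon bound to an oxygen next to a carbonyl group. The step from compound 1 to compound 2, an exchange at the same place, gave a 1.2-fold lower number from compound 1 to compound 2 (0.09 log units; within the scatter). Bringing in phenyl gave a 2.4-fold lower number from compound 1 to compound 3 (0.38 log units; beyond the scatter) and a 1.9-fold lower number from compound 2 to compound 3 (0.29 log units; within the scatter). For the measured compounds named here, a phenyl on the saturated chain carbon has no precedent; a modest move toward a lower number, much of it inside the scatter, is therefore expected. The step expected is a 1.5-fold lower number from compound 2 to compound 4 (0.17 log units; within the scatter). Compound 4 is estimated at 12000 nM in this assay, with a range from 6000 nM to 24000 nM.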

Compound 4, concentration for 50% growth inhibition: 3700 nM
For compound 4 the middle estimate is 3.2-fold (0.51 log units) above the measured one, outside the stated range (below it).
By their numbers in this assay, from the lowest: compound 4; then compounds 3, 2 and 1 (each within the scatter of the next, the first and the last beyond it).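

In this assay, phenyl on a saturated chain carbon bound to an oxygen next to a carbonyl group gives a 4.8-fold lower number from compound 2 to compound 4 (0.68 log units; beyond the scatter) and a 5.8-fold lower number from compound 1 to compound 4 (0.77 log units; beyond the scatter). The earlier exchange at this same carbon gave only a 1.2-fold lower number from compound 1 to compound 2 (0.09 log units; within the scatter), so this place does respond to the group it carries, and among the three groups shown there, only phenyl moves the number beyond the scatter. No measurement at hand explains the size of this step.

The compounds shown leave open whether the shift requires the aromatic ring itself or would also come with a cyclohexyl ring or a longer chain on that carbon, and whether a pyridine ring or a chlorophenyl group would keep it. As far as these compounds go, whether the step holds on any other cell line also remains open.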